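Ethyl in place of iodo on a weakly active core

This account rests on a few compounds, and the source may have more. Where it says the series, first, only, none or still open, it means among the compounds named here.

Measured so far in a functional assay on L1210 cells (Mus musculus) for cytotoxicity; a higher number here means a weaker inhibitor, a lower number a stronger inhibitor:
compound 1 `C=C1C(n2cc(F)c(=O)[nH]c2=O)O[C@H](CO)[C@@H]1O`: > 100 ug/mL
compound 2 `C=C1C(n2cc(I)c(=O)[nH]c2=O)O[C@H](CO)[C@@H]1O`: > 100 ug/mL

In this assay compound 1 gives > 100 ug/mL, which is a limit of the assay and not a number. Compound 2 likewise gives only a limit, > 100 ug/mL. The step that the two limits leave unreadable from compound 1 to compound 2 therefore has no readable size, since (the limit of > 100 ug/mL in this assay, at which 2 of the 2 values shown sit). Compound 3 `C=C1C(n2cc(CC)c(=O)[nH]c2=O)O[C@H](CO)[C@@H]1O` differs from compound 2 by ethyl in place of iodo on an aromatic carbon. Among the measured compounds shown here, no measured step bears on this change with a readable size, so compound 3 is expected to sit near compound 2, with an expected step of a number no higher from compound 2 to compound 3 (the limit leaves the size open). Compound 3 is accordingly estimated at 100 ug/mL, within 40 ug/mL to 300 ug/mL in this assay.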

Compound 3, half-maximal inhibitory concentration: > 100 ug/mL
Compound 3 was reported as a limit (the forecaster's own chance of this, stated with the estimate: 80%); the middle value lies on the limit itself.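

In this assay compound 3 gives > 100 ug/mL, a limit and not a number. Its steps from compound 1 and compound 2 therefore cannot be read: the limit of > 100 ug/mL in this assay, at which 3 of the 3 values shown sit.

The compounds shown leave open whether fluoro, iodo or ethyl on the shared core makes any difference in this assay.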